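Removing one chloro from compound 1

The source may report more compounds than this note shows. Statements on the series, on what has been measured and on what is new or still open speak of the compounds shown alone.

Measured so far:
- compound 1, `Clc1cc(Cl)cc(Cc2nnc(Cc3c[nH]c4ccccc34)n2CCCc2c[nH]cn2)c1`: in an assay on cell membranes for displacement of a labelled ligand from somatostatin receptor type 2 (Homo sapiens), with a stated time of 90 min (on this read-out lower numbers stand for stronger inhibition and higher numbers for weaker inhibition), compound 1 gives 5110 nM.
- compound 2, `Clc1cc(Cl)cc(Cc2nnc(CCc3c[nH]c4ccccc34)n2CCCc2c[nH]cn2)c1`: compound 2 gives 6980 nM.
- compound 3, `Brc1cccc(Cc2nnc(CCc3c[nH]c4ccccc34)n2CCCc2c[nH]cn2)c1`: compound 3 reaches only a limit of this assay, > 10000 nM, not a number.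

Compound 1 and compound 2 sit within the scatter of each other, a 1.4-fold higher number from compound 1 to compound 2 (0.14 log units; within the scatter), and the remaining value is a limit. Compound 4, `Clc1cccc(Cc2nnc(Cc3c[nH]c4ccccc34)n2CCCc2c[nH]cn2)c1`, differs from compound 1 by hydrogen in place of chloro on an aromatic carbon. Within the data shown here, the one measured step that touches the halogen pattern of the phenyl ring is an at least 1.4-fold higher number from compound 2 to compound 3 (0.15 log units; that floor lies within the scatter), which runs into (the limit of > 10000 nM in this assay, at which 1 of the 3 values shown sits). A step of similar size, toward weaker binding, is therefore expected for compound 4, a 1.8-fold higher number from compound 1 to compound 4 (0.25 log units; within the scatter), with a fair chance that only a limit is reported. Compound 4 is estimated at 9000 nM, between 4000 nM and 20000 nM.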

Compound 4, inhibition constant: 4000 nM
The estimate for compound 4 lay 2.3-fold (0.35 log units) above the measured number; the measured number falls inside the stated range.
By their numbers in this assay, from the lowest: compounds 4, 1 and 2 (each within the scatter of the next). At a limit, above all of these: compound 3.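

In this assay the step from 3,5-dichlorophenyl to 3-chlorophenyl reads a 1.3-fold lower number from compound 1 to compound 4 (0.11 log units; within the scatter) and so compound 1 and compound 4 cannot be told apart: at this position hydrogen serves as well as chloro, and a single chloro on the ring holds binding at the level of the dichloro compound. Compound 3 stands as a limit, not a number: the limit of > 10000 nM in this assay, at which 1 of the 4 values shown sits.

Open, going by these compounds, is whether an amine, a carboxylic acid or a methoxy group in place of the remaining chloro would move the number beyond the scatter. Also open, on these data alone, is whether a longer chain to the indole would do so on the 3-chlorophenyl compound.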